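The source may hold more compounds than are shown below. What is called first, only, known or untested is meant among the compounds shown, and "the series" means these compounds.

Compound 1 `Oc1ccc(/C=N/N(Cc2ccccc2)Cc2ccccc2)cc1` gives 2400 nM in an assay on liver (Sus scrofa) for inhibition of glucose-6-phosphatase catalytic subunit 1 (Homo sapiens), using microsomes; on this read-out higher numbers stand for weaker inhibition and lower numbers for stronger inhibition. Compound 2 `C(=N/N(Cc1ccccc1)Cc1ccccc1)\c1cccnc1` gives 3700 nM. Compound 3 `CCc1ccc(/C=N/N(Cc2ccccc2)Cc2ccccc2)o1` gives 330 nM.

Compound 3 stands lowest of the three numbers, with a 7.3-fold lower number from compound 1 to compound 3 (0.86 log units; beyond the scatter) and an 11-fold lower number from compound 2 to compound 3 (1.05 log units; beyond the scatter). Compound 4 `Clc1ccc(/C=N/N(Cc2ccccc2)Cc2ccccc2)s1` differs from compound 3 by 5-chlorothiophen-2-yl in place of 5-ethylfuran-2-yl on a carbon with a double bond to nitrogen. Both measured steps that end at compound 3 exchange the group on the carbon with a double bond to nitrogen, and both were beyond the scatter in favour of the five-membered aromatic ring with 1 hetero atom; neither exchanges one such ring for another, so they bear only loosely here. For compound 4 a step within the scatter, a 1.4-fold higher number from compound 3 to compound 4 (0.13 log units; within the scatter), is expected in this assay. Compound 4 is estimated at 450 nM, between 150 nM and 1400 nM.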

Compound 4, half-maximal inhibitory concentration: 170 nM
Beside the measured number, compound 4's estimate is 2.6-fold (0.42 log units) above it, and the stated range covers the measured number.
By their numbers in this assay, from the lowest: compounds 4 and 3 (each within the scatter of the next); then compounds 1 and 2 (each within the scatter of the next).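

In this assay, exchanging one five-membered aromatic ring with 1 hetero atom for another on the carbon with a double bond to nitrogen gives a 1.9-fold lower number from compound 3 to compound 4 (0.29 log units; within the scatter), so 5-ethylfuran-2-yl and 5-chlorothiophen-2-yl are not separated here. The large gaps to the other groups now recur with a second ring of this kind: a 22-fold lower number from compound 2 to compound 4 (1.34 log units; beyond the scatter) and a 14-fold lower number from compound 1 to compound 4 (1.15 log units; beyond the scatter). Nothing at hand bears on why these rings stand apart from pyridin-3-yl and 4-hydroxyphenyl. On these data alone, whether an amine or a carboxylic acid at this position would keep the number low stays open, as does any change elsewhere on the shared core.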